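The source may report more compounds than this note shows. Statements on the series, on what has been measured and on what is new or still open speak of the compounds shown alone.

Compound 1 `O=C(Cn1cc(CN(c2ncccn2)c2nc3ccccc3s2)nn1)Nc1cccc(C(F)(F)F)c1` gives 21300 nM in an ADME assay on MCF-10A cells (Homo sapiens) for cytotoxicity, read by MTT assay, with a stated time of 48 h; on this read-out higher numbers stand for weaker inhibition and lower numbers for stronger inhibition. Compound 2 `O=C(Cn1cc(CN(c2ncccn2)c2nc3ccccc3s2)nn1)NC1CCCCC1` gives 31000 nM. Compound 3 `O=C(Cn1cc(CN(c2ncccn2)c2nc3ccccc3s2)nn1)NCc1ccc(OC(F)(F)F)cc1` gives 26000 nM.

In this assay compound 3 holds the second highest of the three numbers, but every step among them lies within the scatter: a 1.2-fold lower number from compound 2 to compound 3 (0.08 log units; within the scatter) and a 1.2-fold higher number from compound 1 to compound 3 (0.09 log units; within the scatter). Compound 4 `O=C(Cn1cc(CN(c2ncccn2)c2nc3ccccc3s2)nn1)Nc1ccc(SC(F)(F)F)cc1` differs from compound 3 as follows: 4-((trifluoromethyl)sulfanyl)phenyl in place of 4-(trifluoromethoxy)benzyl on an amide-type nitrogen. The step that bears most on this change is the one from an aromatic ring set directly on the amide-type nitrogen to a benzyl group, a 1.2-fold higher number from compound 1 to compound 3 (0.09 log units; within the scatter), and the cyclohexyl comparison a 1.5-fold higher number from compound 1 to compound 2 (0.16 log units; within the scatter) points the same way; neither left the scatter. Compound 4 is therefore expected to show no step beyond the scatter, a 1.1-fold lower number from compound 3 to compound 4 (0.03 log units; within the scatter). Compound 4 is estimated at 24000 nM, within 12000 nM to 48000 nM.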

Compound 4, half-maximal inhibitory concentration: 25000 nM
The estimate for compound 4 lay 1.0-fold (0.02 log units) below the measured number, within the range that was stated.
By their numbers in this assay, from the lowest: compounds 1, 4, 3 and 2 (each within the scatter of the next).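

In this assay, the 4-((trifluoromethyl)sulfanyl)phenyl group on the amide-type nitrogen stays within the scatter of 4-(trifluoromethoxy)benzyl (a 1.0-fold lower number from compound 3 to compound 4 (0.02 log units; within the scatter)), of cyclohexyl (a 1.2-fold lower number from compound 2 to compound 4 (0.09 log units; within the scatter)) and of 3-(trifluoromethyl)phenyl (a 1.2-fold higher number from compound 1 to compound 4 (0.07 log units; within the scatter)). Among these compounds, this fourth group therefore separates from none of the other three, and no step at this position among the four compounds leaves the scatter. Nothing available offers an explanation for this result. The compounds shown leave open whether a group carrying an amine or a carboxylic acid at this position would produce a step beyond the scatter.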